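The source may report more compounds than this note shows. Statements on the series, on what has been measured and on what is new or still open speak of the compounds shown alone.

Compound 2 `CCc1ccc2[nH]cc(-c3nn[nH]n3)c(=O)c2c1` is the starting point. In a functional assay on the whole organism (strain Sprague-Dawley) for inhibition, with Rattus norvegicus as the target (a lower number here means that less compound is needed, a higher number that more compound is needed for the effect), compound 2 gives < 5 mg/kg, which is a limit of the assay rather than a number. Compound 1 `O=c1c(-c2nn[nH]n2)c[nH]c2ccc(Cl)cc12` differs from compound 2 only by ethyl in place of chloro on an aromatic carbon. In this assay compound 1 gives > 10 mg/kg, again a limit. That single measured step reads an at least 2.0-fold lower number from compound 1 to compound 2 (0.30 log units; that floor lies within the scatter). Compound 3 `COc1ccc2ncc(C(=O)O)cc2c1` rests on a different core. In this assay compound 3 gives > 5 mg/kg, a limit as well. Compound 2 thus sits at the limit of < 5 mg/kg in this assay, at which 1 of the 3 values shown sits. Compound 4 `Cc1ccc2[nH]cc(-c3nn[nH]n3)c(=O)c2c1` is the untested member, and its change from compound 2 is hydrogen in place of methyl on a saturated chain carbon bound to an aromatic carbon. Going by the values given here, the one measured step, from compound 1 to compound 2, exchanged chloro for ethyl; no measured step exchanges ethyl for methyl, so nothing here bears directly on the present change. The expectation for the step to compound 4 is therefore a step that the limit leaves unreadable from compound 2 to compound 4, within the scatter. Compound 4 is estimated at 4 mg/kg, with a range from 1.5 mg/kg to 12 mg/kg.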

Compound 4, minimum effective dose: 1.25 mg/kg
The estimate for compound 4 lay 3.2-fold (0.51 log units) above the measured number; measured number outside the range, below it.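

In this assay compound 4 gives 1.25 mg/kg, the only actual number among the compounds shown. All the other values shown are limits of the assay. Exchanging chloro for methyl on this aromatic carbon reads an at least 8.0-fold lower number from compound 1 to compound 4 (0.90 log units; beyond the scatter), so a non-halogen alkyl group at this position is now clearly separated from chloro, which the earlier step to ethyl could not establish because its floor lay within the scatter. Shortening ethyl to methyl cannot be given a size, because compound 2 stands at a limit of the assay: the limit of < 5 mg/kg in this assay, at which 1 of the 4 values shown sits.

On these data alone, whether ethyl and methyl truly differ therefore remains open. Also open, as far as these compounds go, is how a longer chain such as propyl, or an amine, would read at this same aromatic carbon on the shared core.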